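The source may hold more compounds than are shown below. What is called first, only, known or untested is meant among the compounds shown, and "the series" means these compounds.

Working notes on the series.

Compound 1 `Cc1noc(C)c1-c1cnc(N)c(Oc2ccc(C(=O)Nc3ccccc3)cc2)n1` carries the shared core with a phenyl on the amide-type nitrogen; in a functional assay on HepG2 cells (Homo sapiens) for inhibition, read by MTT assay, with a stated time of 72 h (on this read-out higher numbers stand for weaker inhibition and lower numbers for stronger inhibition), compound 1 gives 11800 nM. Compound 2 `Cc1noc(C)c1-c1cnc(N)c(Oc2ccc(C(=O)Nc3ncccc3Cl)cc2)n1` differs only on that nitrogen, and compound 2 gives 27200 nM, a change of a 2.3-fold higher number from compound 1 to compound 2 (0.36 log units; beyond the scatter). Compound 3 `Cn1cc(-c2cnc(N)c(Oc3ccc(C(=O)Nc4ccccc4)cc3)n2)cn1` differs from compound 1 on the aromatic carbon, and compound 3 gives 11600 nM, the lowest of the three numbers, though the step of a 1.0-fold lower number from compound 1 to compound 3 (0.01 log units; within the scatter) is within the scatter. Compound 4 `Cn1cc(-c2cnc(N)c(Oc3ccc(C(=O)Nc4cc(Cl)ccn4)cc3)n2)cn1` has not yet been measured. The change from compound 3 to compound 4 is 4-chloropyridin-2-yl in place of phenyl on an amide-type nitrogen. Going by the values given here, the only measured step that bears on it is the one from compound 1 to compound 2, where a chloropyridinyl entered in place of phenyl on the same nitrogen and gave a 2.3-fold higher number from compound 1 to compound 2 (0.36 log units; beyond the scatter). A step of similar direction and size is therefore expected, that is a higher number in this assay, estimated as a 1.9-fold higher number from compound 3 to compound 4 (0.28 log units; within the scatter). The estimate for compound 4 in this assay is 22000 nM, with a range from 9000 nM to 55000 nM.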

Compound 4, half-maximal inhibitory concentration: > 100000 nM
Compound 4 gave a limit, no number (the forecaster's own chance of this, stated with the estimate: 10%); middle value at least 4.5-fold (0.65 log units) from the limit.
By their numbers in this assay, from the lowest: compounds 3 and 1 (each within the scatter of the next); then compound 2. At a limit, above all of these: compound 4.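

Compound 4 gives a limit in this assay, not a number: the limit of > 100000 nM in this assay, at which 1 of the 4 values shown sits. As far as these compounds go, on the amide-type nitrogen, 4-chloropyridin-2-yl in place of phenyl gives an at least 8.6-fold higher number from compound 3 to compound 4 (0.93 log units; beyond the scatter), a much larger step at this position than the earlier 2.3-fold higher number from compound 1 to compound 2 (0.36 log units; beyond the scatter), and its true size stays unknown. Both chloropyridinyl replacements of phenyl raise the number, so the direction holds across the two pairs, which differ both in the chloropyridinyl group and in the group on the aromatic carbon.

Those two differences cannot be separated here, as 4-chloropyridin-2-yl is shown only with 1-methyl-1H-pyrazol-4-yl and 3-chloropyridin-2-yl only with 3,5-dimethyl-1,2-oxazol-4-yl. Also open, from the compounds shown here alone, is how pyridin-2-yl without the chlorine, or with a methoxy group in place of that chlorine, would read on this nitrogen.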